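Bromo to chloro swap across two cores of the series

A few compounds are considered here, and "the series" means these few. Any claim that something is new, unique, unknown or untested is made for them only; others in the source may bear on it.

In a functional assay on cells (Cancer cell lines, Homo sapiens) for cytotoxicity, read by sulforhodamine B assay, with a stated time of 48 h (a higher number here means a weaker inhibitor of growth, a lower number a stronger inhibitor of growth), compound 1 `CN(C)c1ccc(C2CC(c3ccccc3)=NN2C2=NC(=O)/C(=C3\C(=O)Nc4ccc(Br)cc43)S2)cc1` gives 200 nM, and compound 2 `CN(C)c1ccc(C2CC(c3ccccc3)=NN2C2=NC(=O)/C(=C3\C(=O)Nc4ccc(Cl)cc43)S2)cc1` gives 190 nM. The change between them, (chloro in place of bromo on an aromatic carbon), made a step of a 1.1-fold lower number from compound 1 to compound 2 (0.02 log units; within the scatter). Compound 3 `COc1ccc(-c2cc(-c3ccc(Cl)cc3)n(C3C(=O)Nc4ccc(Br)cc43)n2)cc1` rests on a different core; the difference between the two cores is not broken down here. In this assay compound 3 gives 7200 nM, which leaves it well apart from compound 1 and compound 2. Compound 4 `COc1ccc(-c2cc(-c3ccc(Cl)cc3)n(C3C(=O)Nc4ccc(Cl)cc43)n2)cc1` is compound 3 with the same change, (chloro in place of bromo on an aromatic carbon), the place being the same as in the step from compound 1 to compound 2. Within the data shown here, since that earlier step stayed within the scatter, the step from compound 3 to compound 4 is expected to be about a 1.0-fold lower number from compound 3 to compound 4 (0.01 log units; within the scatter), and in this assay compound 4 is expected at roughly 7000 nM, with a range of 3500 nM to 14000 nM, because the only guide for this swap is the step of a 1.1-fold lower number from compound 1 to compound 2 (0.02 log units; within the scatter) on a core that is not the core of compound 3.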

Compound 4, concentration for 50% growth inhibition: 6150 nM
The estimate for compound 4 lay 1.1-fold (0.06 log units) above the measured number; low and high end bracket the measured number.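

In this assay, chloro in place of bromo on an aromatic carbon gave a step of a 1.2-fold lower number from compound 3 to compound 4 (0.07 log units; within the scatter), and the swap behaved alike on the two cores: the same change on two cores in this assay, a 1.1-fold lower number (0.02 log units; within the scatter) from compound 1 to compound 2 and a 1.2-fold lower number (0.07 log units; within the scatter) from compound 3 to compound 4, 1.1-fold (0.05 log units) apart, within the scatter of two such steps. On the core of compound 1 and the core of compound 3 alike, the two halogens are therefore interchangeable at this place in this read-out, even though the two cores sit at very different levels of growth inhibition. Among these compounds, this rests on only two matched pairs, and it does not show that the swap would stay within the scatter on any further core, nor does it explain why the two halogens read alike.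

The compounds shown carry only bromo or chloro on this aromatic carbon, so the outcome with fluoro, a methoxy group or an amine at the same place remains open. Also open is which part of the core of compound 1 sets it apart from the core of compound 3, since no pair shown isolates a single feature of that difference.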